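Swapping a Nitrile for a Cyclohexyl Ring

The source may report more compounds than this note shows. Statements on the series, on what has been measured and on what is new or still open speak of the compounds shown alone.

Three related compounds share one core and have been tested in an ADME assay on HEL cells (Homo sapiens) for cytotoxicity, with a stated time of 3 days; a lower number here means that less compound is tolerated, a higher number that more compound is tolerated. Compound 1 `CCC1(Cc2ccccc2)OS(=O)(=O)C=C1OCC#N` carries a cyanomethoxy group on that core. In this assay compound 1 gives > 200000 nM, which is a limit of the assay rather than a measured number. Compound 1 therefore stands at the limit of > 200000 nM in this assay, at which 1 of the 3 values shown sits, and nothing more precise about its own position is known. Compound 2 `CCC1(Cc2ccccc2)OS(=O)(=O)CC1=O` has a ketone in place of the side chain, and in this assay compound 2 gives 200000 nM. Compound 3 `CCC1(Cc2ccccc2)OS(=O)(=O)C=C1OS(=O)(=O)c1ccc(C)cc1` carries a sulfonate ester instead, and in this assay compound 3 gives 109000 nM. Among the measured compounds shown here, no two of these measured compounds differ in only one place, so there is no measured single step to lean on.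

Compound 4 `CCC1(Cc2ccccc2)OS(=O)(=O)C=C1OCC1CCCCC1` is not yet measured. Relative to compound 1 it shows (cyclohexyl in place of cyano on a saturated chain carbon bound to an oxygen on an unsaturated carbon). With compound 1 sitting at a limit, the step from compound 1 to compound 4 is expected to be an at least 1.6-fold lower number from compound 1 to compound 4 (0.22 log units; that floor lies within the scatter), a modest move downward that may not clear the scatter. For compound 4 in this assay a value of 120000 nM is estimated, with a range from 40000 nM to 250000 nM.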

Compound 4, half-maximal cytotoxic concentration: > 200000 nM
Compound 4: a limit, no number; the forecaster's own chance of this, stated with the estimate: 35%; middle value at least 1.6-fold (0.22 log units) away from the limit.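

In this assay compound 4 gives > 200000 nM, which is a limit of the assay and not a number. Compound 1 stands at the same limit, so no step between compound 1 and compound 4 can be read: the limit of > 200000 nM in this assay, at which 2 of the 4 values shown sit.

The compounds shown leave open whether cyclohexyl in place of cyano changes the tolerated concentration at all.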